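Swapping methoxy for methyl at an assay limit

The compounds below may be only part of what the source reports. "The series", "measured", "known", "first", "only" and "open" are said of these compounds alone.

Compound 1 `COC(=O)C1CCN(c2cc(Cl)c(C(=O)Nc3cc(-c4nc5ccccc5s4)ccc3C)cc2[N+](=O)[O-])CC1`: > 25000 nM
Compound 2 `COc1ccc(-c2nc3ccccc3s2)cc1NC(=O)c1cc([N+](=O)[O-])ccc1Cl`: > 25000 nM

Both values come from an ADME assay on Raji cells (Homo sapiens) for cytotoxicity, with a stated time of 72 h; on this read-out higher numbers stand for an effect only at larger amounts of compound and lower numbers for an effect already at smaller amounts. Compound 2 gives > 25000 nM, which is a limit of the assay and not a number. Compound 1 gives > 25000 nM, also a limit. Among the measured compounds shown here, the picture so far is therefore (the limit of > 25000 nM in this assay, at which 2 of the 2 values shown sit), and no measured pair isolates a single structural change.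

Compound 3 `Cc1ccc(-c2nc3ccccc3s2)cc1NC(=O)c1cc([N+](=O)[O-])ccc1Cl` differs from compound 2 by methyl in place of methoxy on an aromatic carbon, ortho to a large group and para to a 1,3-benzothiazol-2-yl group: methyl in place of methoxy on an aromatic carbon. In this assay the expected change, a number no higher from compound 2 to compound 3 (the limit leaves the size open), is none beyond the usual scatter. Compound 3 is estimated at 25000 nM, with an expected range of 10000 nM to 40000 nM, and it may well be reported only as a limit.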

Compound 3, half-maximal effective concentration: > 14000 nM
Compound 3: only a limit was reported (the forecaster's own chance of this, stated with the estimate: 75%); the middle value does not contradict the limit.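

In this assay, among the compounds shown here, compound 3 gives > 14000 nM, a limit and not a number; the values of compound 1 and compound 2 are limits as well, so no step to compound 3 can be read. From the compounds shown here alone, what remains open is whether methyl in place of methoxy changes the read-out at all, and the actual value of each of the three compounds.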